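The compounds below may be only part of what the source reports. "The series", "measured", "known", "first", "only" and "open" are said of these compounds alone.

Measured in an assay on isolated protein for inhibition of MAP kinase-interacting serine/threonine-protein kinase 1 (Homo sapiens), read by HTRF, in the presence of a further agent that is not named here; on this read-out lower numbers stand for stronger inhibition and higher numbers for weaker inhibition:
compound 1, `CNC(=O)c1cccc(C#Cc2ccccc2Nc2ncnc3ccc(Cl)nc23)c1`: > 10000 nM
compound 2, `CCCNC(=O)c1cccc(C#Cc2ccccc2Nc2ncnc3ccc(Cl)nc23)c1`: > 10000 nM
compound 3, `CCCNC(=O)c1oc2ccc(Nc3ncnc4ccc(Cl)nc34)cc2c1C`: > 10000 nM

The reading for compound 1 is a limit of the assay, not a number. The reading for compound 2 is likewise a limit. The reading for compound 3 is also a limit. All three therefore sit at the same boundary, as summarised by the limit of > 10000 nM in this assay, at which 3 of the 3 values shown sit, and none of them says how weak the inhibition actually is.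

Compound 1 and compound 2 share one core and differ only in hydrogen in place of ethyl on a saturated chain carbon bound to an amide-type nitrogen. Both readings are limits. The step that the two limits leave unreadable from compound 2 to compound 1 cannot be sized: the two compounds may be equal or far apart, and this assay cannot tell.

Compound 3 carries a different core; how the two cores differ is not broken down here. Among the compounds with values here, compound 4, `CNC(=O)c1oc2ccc(Nc3ncnc4ccc(Cl)nc34)cc2c1C`, is not yet measured and differs from compound 3 by hydrogen in place of ethyl on a saturated chain carbon bound to an amide-type nitrogen, the same change at the same kind of place as the one from compound 2 to compound 1.

The expectation for compound 4 rests on the fact that compound 3 gives > 10000 nM, a limit, and that the earlier instance of this change was unreadable, a step that the two limits leave unreadable from compound 2 to compound 1. The step from compound 3 to compound 4 is therefore expected to be a step that the limit leaves unreadable from compound 3 to compound 4, with the reading most likely remaining a limit. Compound 4 is estimated to give about 25000 nM, with a plausible range from 8000 nM to 100000 nM.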

Compound 4, half-maximal inhibitory concentration: > 10000 nM
Compound 4: no number, only a limit; the forecaster's own chance of this, stated with the estimate: 85%; the middle value lies beyond the limit too.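

In this assay compound 4 gives > 10000 nM, which is a limit and not a number. No step can therefore be read between compound 3 and compound 4, and all the compounds shown sit at the same boundary: the limit of > 10000 nM in this assay, at which 4 of the 4 values shown sit.

From the compounds shown here alone, what stays open is how weak each of the four compounds really is, and whether the two cores or the propyl and methyl chains differ at all in inhibition.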